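Methylamino in place of morpholin-4-yl on a carbonyl carbon

The source may report more compounds than this note shows. Statements on the series, on what has been measured and on what is new or still open speak of the compounds shown alone.

In a functional assay on MDA-MB-231 cells (Homo sapiens) for inhibition, read by sulforhodamine B assay, with a stated time of 72 h (on this read-out lower numbers stand for stronger inhibition of growth and higher numbers for weaker inhibition of growth), compound 1 `NNC(=O)CCc1ccncc1-c1ccc2ccccc2c1` gives > 10000 nM, which is a limit of the assay. Compound 2 `O=C(CCc1ccncc1-c1ccc2ccccc2c1)N1CCOCC1` gives > 10000 nM, also a limit and not a number. Compound 3 `CNC(=O)CCc1ccncc1-c1ccc2ccccc2c1` differs from compound 2 as follows: methylamino in place of morpholin-4-yl on a carbonyl carbon. Within the data shown here, the only measured step that bears on this change is a step that the two limits leave unreadable from compound 1 to compound 2, and it sits at the limit of > 10000 nM in this assay, at which 2 of the 2 values shown sit, so it offers no size to carry over. No step beyond the scatter is therefore expected in either direction, and the estimated step is a step that the limit leaves unreadable from compound 2 to compound 3. For compound 3 the estimate is 15000 nM, with an expected range of 5000 nM to 40000 nM.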

Compound 3, concentration for 50% growth inhibition: 8980 nM
For compound 3 the middle estimate is 1.7-fold (0.22 log units) above the measured one, and the stated range covers the measured number.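

The series now holds its first value in this assay that is a number and not a limit, yet the change can only be bounded: an at least 1.1-fold lower number from compound 2 to compound 3 (0.04 log units; that floor lies within the scatter), and an at least 1.1-fold lower number from compound 1 to compound 3 (0.04 log units; that floor lies within the scatter). Both floors lie within the scatter, so neither methylamino in place of morpholin-4-yl nor methyl in place of amino on an amide-type nitrogen is shown to shift growth inhibition. The remaining values are limits: the limit of > 10000 nM in this assay, at which 2 of the 3 values shown sit. From the compounds shown here alone, whether a longer chain on that nitrogen, or a terminal amine on such a chain, would give a clearly lower number stays open.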